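Removing the Nitrile from Compound 1: an Expected Outcome

This account rests on a few compounds, and the source may have more. Where it says the series, first, only, none or still open, it means among the compounds named here.

Measured compounds:
compound 1, `CCOc1ccc(Br)cc1-c1cc(Nc2cccc(C#N)c2)nc(N)n1`: 720 nM
compound 2, `Cc1ccc(Cl)cc1-c1cc(Nc2ccc(Br)cc2)nc(N)n1`: 34 nM
compound 3, `Cc1ccc(Br)cc1-c1cc(Nc2ccc(Br)cc2)nc(N)n1`: 18 nM

Three compounds sharing one core have been examined in an assay on Sf9 cells for inhibition of 1-acyl-sn-glycerol-3-phosphate acyltransferase beta (Homo sapiens); a higher number here means a weaker inhibitor, a lower number a stronger inhibitor. Compound 1 gives 720 nM, the highest of the three numbers; the nearest is compound 2 with 34 nM, and compound 3 with 18 nM lies furthest away, both gaps being beyond the scatter. For the measured compounds named here, the only single-point step measured, a 1.9-fold lower number from compound 2 to compound 3 (0.28 log units; within the scatter), concerns bromo in place of chloro on an aromatic carbon of the other ring and does not touch the aniline.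

Compound 4, `CCOc1ccc(Br)cc1-c1cc(Nc2ccccc2)nc(N)n1`, differs from compound 1 by hydrogen in place of cyano on an aromatic carbon. Going by the values given here, no measured step bears directly on this change; compounds 2 and 3 carry a different substitution on the aniline ring and also differ elsewhere, so they offer no clean comparison. For compound 4 the step of a 1.1-fold lower number from compound 1 to compound 4 (0.04 log units; within the scatter) is therefore expected to stay within the scatter of this assay. Compound 4 is estimated at 650 nM, with a range from 200 nM to 2500 nM.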

Compound 4, half-maximal inhibitory concentration: 120 nM
Compound 4: middle estimate off by 5.4-fold (0.73 log units), on the high side; the whole stated range lies above it.
By their numbers in this assay, from the lowest: compounds 3 and 2 (each within the scatter of the next); then compound 4; then compound 1.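

Removing the nitrile is not a neutral change in this assay, as a 6.0-fold lower number from compound 1 to compound 4 (0.78 log units; beyond the scatter) shows that this position, meta to a large group, responds to its substituent. Going from 3-cyanophenyl to phenyl is the first measured step on this ring, since the bromo for chloro step from compound 2 to compound 3 lay on the other ring, and here the plain phenyl gives the lower number. No measurement shown explains why the number falls with this change.

Going by these compounds, it remains open whether other groups at this position, such as an amine, a methoxy group or a carboxylic acid, would give numbers nearer to compound 1 or to compound 4. On these data alone, it is also open whether the same change would give a step of similar size with methyl in place of the ethoxy group.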